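Replacing Acetyl with Methyl on a Sulfur

A few compounds are considered here, and "the series" means these few. Any claim that something is new, unique, unknown or untested is made for them only; others in the source may bear on it.

In an ADME assay on HEK293 cells (Homo sapiens) for inhibition, read by MTT assay, with a stated time of 96 h (on this read-out lower numbers stand for stronger inhibition of growth and higher numbers for weaker inhibition of growth), compound 1 `CCCC(=O)SCCCCCCNC(=O)c1cc(-c2ccncc2)n[nH]1` gives > 50000 nM as a limit of the assay, not a number. Compound 2 `CC(=O)SCCCCCCNC(=O)c1cc(-c2ccncc2)n[nH]1` gives > 50000 nM as a limit too, so it offers no number to step from. The pair therefore shows only the limit of > 50000 nM in this assay, at which 2 of the 2 values shown sit, and no graded trend. For the measured compounds named here, the one measured step is a step that the two limits leave unreadable from compound 1 to compound 2 and it also concerns the group on the sulfur.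

methyl in place of acetyl on a sulfur is the change that gives compound 3 `CSCCCCCCNC(=O)c1cc(-c2ccncc2)n[nH]1`, methyl in place of acetyl on a sulfur. No step beyond the scatter is expected in either direction in this assay because a step that the two limits leave unreadable from compound 1 to compound 2 gives no size to carry over. The expected step is a number no higher from compound 2 to compound 3 (the limit leaves the size open) on this estimate. Compound 3 is estimated at 50000 nM with an expected range from 25000 nM to 100000 nM for the coming measurement.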

Compound 3, concentration for 50% growth inhibition: > 50000 nM
Compound 3: no number, only a limit; the forecaster's own chance of this, stated with the estimate: 85%; the middle value lies on the limit itself.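

In this assay compound 3 gives a limit, not a number, so no step among compound 1, compound 2 and compound 3 can be read, and all three stand together: the limit of > 50000 nM in this assay, at which 3 of the 3 values shown sit.

Going by these compounds, whether the group on the sulfur affects growth inhibition in this assay stays open with these compounds.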